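Trimming an alkoxy chain on a corticotropin-releasing factor ligand

The compounds below may be only part of what the source reports. "The series", "measured", "known", "first", "only" and "open" are said of these compounds alone.

Compound 1 `CCOc1nc(-c2ccc(Cl)cc2Cl)c(CC)nc1NC(CC)CC` is the weakest of the three measured compounds, giving 151 nM in an assay on IMR-32 cells for displacement of a labelled ligand from corticotropin-releasing factor receptor 1 (Homo sapiens), read by scintillation counting, with a stated time of 2 h; on this read-out higher numbers stand for weaker inhibition and lower numbers for stronger inhibition. Compound 2 `CCc1nc(NC(CC)CC)c(OC)nc1-c1ccc(Cl)cc1Cl` differs from it by hydrogen in place of methyl on a saturated chain carbon bound to an oxygen on an aromatic ring, and that change gave a 26-fold lower number from compound 1 to compound 2 (1.41 log units; beyond the scatter). Compound 3 `CCc1nc(-c2ccc(OC(C)C)cc2OC)c(CC)nc1NC(CC)CC` gives 4.2 nM in this assay, close to compound 2, which gives 5.9 nM; the difference between the cores of compound 3 and compound 1 is not broken down here. Compound 4 `CCOc1ccc(-c2nc(CC)c(NC(CC)CC)nc2CC)c(OC)c1` is not yet measured; it differs from compound 3 by hydrogen in place of methyl on a saturated chain carbon bound to an oxygen on an aromatic ring and a saturated chain carbon, the same kind of change, though here the carbon is also bound to a saturated chain carbon. Since compound 3 already sits low, a smaller step is expected, a 1.7-fold lower number from compound 3 to compound 4 (0.23 log units; within the scatter), and compound 4 is estimated at 2.5 nM, between 0.8 nM and 8 nM.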

Compound 4, inhibition constant: 7.8 nM
For compound 4 the middle estimate is 3.1-fold (0.49 log units) below the measured one; measured number inside the range.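

Replacing methyl with hydrogen, which turns isopropoxy into ethoxy, gave a 1.9-fold higher number from compound 3 to compound 4 (0.27 log units; within the scatter) in this assay. Set beside the earlier step on the core of compound 1, the same change did not carry over in size: the same change on two cores in this assay, a 26-fold lower number (1.41 log units; beyond the scatter) from compound 1 to compound 2 and a 1.9-fold higher number (0.27 log units; within the scatter) from compound 3 to compound 4, 48-fold (1.68 log units) apart, beyond the scatter of two such steps. The large step seen on one core therefore does not transfer as a fixed amount to the other, but two steps cannot show which feature of the cores sets the gap, or how the change would behave on a further core.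

The compounds shown leave open how a propoxy chain or a cyclopropylmethoxy group in place of the ethoxy of compound 4 would read on this core.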